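From acetamido to trifluoromethyl at the stability limit

A few compounds are considered here, and "the series" means these few. Any claim that something is new, unique, unknown or untested is made for them only; others in the source may bear on it.

- Compound 1 `COc1ccc(-c2c(C)nc3c(N4CC[C@@H](NS(=O)(=O)C(C)C)C4)cc(C)nn23)cc1OC`: > 95% (a limit)
- Compound 2 `COc1ccc(-c2c(C)nc3c(N4CC[C@@H](NS(=O)(=O)c5ccc(C)cc5)C4)cc(C)nn23)cc1OC`: > 95% (a limit)
- Compound 3 `COc1ccc(-c2c(C)nc3c(N4CC[C@@H](NS(=O)(=O)c5ccc(NC(C)=O)cc5)C4)cc(C)nn23)cc1OC`: > 95% (a limit)

These three results come from an ADME assay on microsomes from liver (Homo sapiens) for metabolic stability, read by LC-MS, with NADPH named in the record, with a stated time of 60 min, tested at 1 uM, in the absence of a further agent; on this read-out lower numbers stand for a less stable compound and higher numbers for a more stable compound. Compound 3 gives > 95%, which is a limit of the assay and not a number. The same holds across the series: the limit of > 95% in this assay, at which 3 of the 3 values shown sit.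

Compound 4 `COc1ccc(-c2c(C)nc3c(N4CC[C@@H](NS(=O)(=O)c5ccc(C(F)(F)F)cc5)C4)cc(C)nn23)cc1OC` differs from compound 3 in one place: trifluoromethyl in place of acetamido on an aromatic carbon. Trifluoromethyl stands in place of acetamido on an aromatic carbon, para to a large group.

The closest measured change is a step that the two limits leave unreadable from compound 2 to compound 3, which puts acetamido in place of methyl on an aromatic carbon. The group on the sulfonyl sulfur also changes in a step that the two limits leave unreadable from compound 1 to compound 2 and in a step that the two limits leave unreadable from compound 1 to compound 3. None of these steps has a readable size, but all three compounds stay at the limit, and none of them goes against that. On the strength of a step that the two limits leave unreadable from compound 2 to compound 3, no change beyond the usual scatter is expected in this assay, although a hidden difference cannot be ruled out.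

The expected move is a step that the limit leaves unreadable from compound 3 to compound 4, and this is only an estimate. For compound 4 the estimated value is 96%, with an expected range from 86% to 100%.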

Compound 4, percent of the compound remaining: > 95%
Compound 4 was reported as a limit (the forecaster's own chance of this, stated with the estimate: 60%); the middle value is on the limit's open side.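

In this assay compound 4 gives > 95%, which is a limit and not a number. The steps to compound 4 from compound 1, compound 2 and compound 3 cannot be read, because all four compounds share one limit: the limit of > 95% in this assay, at which 4 of the 4 values shown sit. On these data alone, whether the groups on the sulfonyl sulfur differ in stability at all stays open.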